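Hydrazone aryl swap on the shared core: compound 4

The compounds below may be only part of what the source reports. "The series", "measured", "known", "first", "only" and "open" are said of these compounds alone.

compound 1 `Cn1c(=O)c(=O)n(C2CCCC2)c2nc(N/N=C/c3ccc(Cl)cc3)ncc21` — 9810 nM
compound 2 `Cn1c(=O)c(=O)n(C2CCCC2)c2nc(N/N=C/c3cc(C(F)(F)F)c(O)c(C(F)(F)F)c3)ncc21` — 27100 nM
compound 3 `Cn1c(=O)c(=O)n(C2CCCC2)c2nc(N/N=C/c3cccs3)ncc21` — 52600 nM

In a functional assay on HCT-116 cells (Homo sapiens) for antiproliferative activity, read by MTT assay (on this read-out lower numbers stand for stronger inhibition and higher numbers for weaker inhibition), compound 3 gives the highest number of the three. Its gap to compound 2 lies within the scatter, so no order between these two can be read; its gap to compound 1 lies beyond it, as a 5.4-fold higher number from compound 1 to compound 3 (0.73 log units; beyond the scatter) shows. Compound 4 `Cn1c(=O)c(=O)n(C2CCCC2)c2nc(N/N=C/c3ccc(O)c(Br)c3)ncc21` differs from compound 3 in one place: 3-bromo-4-hydroxyphenyl in place of thiophen-2-yl on a carbon with a double bond to nitrogen. Among the compounds with values here, the one measured step that bears on this change is a 5.4-fold higher number from compound 1 to compound 3 (0.73 log units; beyond the scatter), in which a six-membered aromatic ring of carbon only gave way to thiophen-2-yl and the number rose. Compound 4 runs the other way, returning to a six-membered aromatic ring of carbon only. Compound 2 also carries such a ring, yet its number sits within the scatter of compound 3, so the return need not recover the whole of that step. For compound 4 a modest downward step is expected, a 3.3-fold lower number from compound 3 to compound 4 (0.52 log units; beyond the scatter). Compound 4 is estimated at 16000 nM, with a range from 5000 nM to 45000 nM.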

Compound 4, half-maximal inhibitory concentration: 17700 nM
Compound 4: the middle estimate sits 1.1-fold (0.04 log units) below what was measured; the range from low to high includes it.
By their numbers in this assay, from the lowest: compounds 1, 4, 2 and 3 (each within the scatter of the next, the first and the last beyond it).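

In this assay the step of a 3.0-fold lower number from compound 3 to compound 4 (0.47 log units; beyond the scatter) places 3-bromo-4-hydroxyphenyl on the lower side of thiophen-2-yl on this carbon with a double bond to nitrogen, while the step of a 1.8-fold higher number from compound 1 to compound 4 (0.26 log units; within the scatter) leaves 3-bromo-4-hydroxyphenyl and 4-chlorophenyl without an order. A six-membered aromatic ring of carbon only therefore gives a lower number than thiophen-2-yl in compound 1 and compound 4, but compound 2 goes against this pattern, standing within the scatter of compound 3. Nothing at hand accounts for these differences.

Going by these compounds, the separate shares of the bromine and the hydroxy group in compound 4 remain open. Also open, on these data alone, is where an amine or a carboxylic acid on the phenyl ring would fall in this order.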